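This account rests on a few compounds, and the source may have more. Where it says the series, first, only, none or still open, it means among the compounds named here.

Measured so far in a functional assay on A549 cells (Homo sapiens) for inhibition, read by MTT assay, with a stated time of 24 h; on this read-out lower numbers stand for stronger inhibition of growth and higher numbers for weaker inhibition of growth:
- compound 1 `Cn1cc(-c2nc3ccccc3n2C(=O)c2ccccc2)c2ccccc21`: 19600 nM
- compound 2 `COc1ccccc1C(=O)n1c(-c2cn(C)c3ccccc23)nc2ccccc21`: 12300 nM
- compound 3 `COc1ccc2c(c1)c(-c1nc3ccccc3n1C(=O)c1ccccc1)cn2C`: 16700 nM

The value of compound 3 sits within the usual scatter of the values of both compound 1 and compound 2, so these three numbers cannot be put in a firm order.

The next compound is compound 4 `COc1ccc2c(c1)c(-c1nc3ccccc3n1C(=O)c1ccccc1OC)cn2C`. It keeps everything in compound 3 and turns the phenyl of the benzoyl group into 2-methoxyphenyl: methoxy in place of hydrogen on an aromatic carbon.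

Within the data shown here, the closest precedent is the same change made on a different parent, a 1.6-fold lower number from compound 1 to compound 2 (0.20 log units; within the scatter). The other measured step, a 1.2-fold lower number from compound 1 to compound 3 (0.07 log units; within the scatter), places a methoxy elsewhere in the molecule, so it bears only indirectly, but it shows that this group has so far moved the number little. Among the measured compounds shown here, compound 4 carries both methoxy groups, and no measured compound yet shows whether their steps add up.

A small step towards a lower number is therefore the expectation, not one clearly beyond the scatter. The expected step is a 1.5-fold lower number from compound 3 to compound 4 (0.18 log units; within the scatter). For compound 4 the estimate is 11000 nM, with an expected range from 6000 nM to 20000 nM.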

Compound 4, concentration for 50% growth inhibition: 11900 nM
Estimate against measurement, compound 4: 1.1-fold (0.03 log units) below; the measured number falls inside the stated range.
By their numbers in this assay, from the lowest: compounds 4, 2, 3 and 1 (each within the scatter of the next).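

In this assay, turning the phenyl of the benzoyl group into 2-methoxyphenyl has now been tried on a second core, where it gives a 1.4-fold lower number from compound 3 to compound 4 (0.15 log units; within the scatter), so the small step seen earlier recurs at a similar size: the same change on two cores in this assay, a 1.6-fold lower number (0.20 log units; within the scatter) from compound 1 to compound 2 and a 1.4-fold lower number (0.15 log units; within the scatter) from compound 3 to compound 4, 1.1-fold (0.06 log units) apart, within the scatter of two such steps

The other methoxy can now also be read with the 2-methoxyphenyl already in place, where it gives a 1.0-fold lower number from compound 2 to compound 4 (0.01 log units; within the scatter), a step that agrees with the one measured without that group: the same change on two cores in this assay, a 1.2-fold lower number (0.07 log units; within the scatter) from compound 1 to compound 3 and a 1.0-fold lower number (0.01 log units; within the scatter) from compound 2 to compound 4, 1.1-fold (0.06 log units) apart, within the scatter of two such steps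

Each single methoxy step stays within the scatter whether or not the other methoxy is present, so neither place has yet shown a firm effect on the number, and these pairs give no sign that one methoxy depends on the other.

The compounds shown carry only hydrogen or methoxy at these two places, so how far the number can move there remains unknown. Going by these compounds, whether a different group in place of the methoxy on the benzoyl ring, such as an amine or a carboxylic acid, would give a step beyond the scatter stays open.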